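The compounds below may be only part of what the source reports. "The series", "measured", "known", "first", "only" and "open" are said of these compounds alone.

Measured so far, in a functional assay, read by spectrophotometry, with a stated time of 15 min, tested at 20 ug/mL; on this read-out higher numbers stand for a stronger effect at the one concentration tested and lower numbers for a weaker effect:

Compound 1 `Fc1ccc(-c2csc(N/N=C/c3ccc(Cl)cc3Cl)n2)cc1` gives 88.4%.
Compound 2 `Cc1ccc(-c2csc(N/N=C/c3ccc(Cl)cc3Cl)n2)cc1` gives 76.2%.
Compound 3 `Fc1ccc(-c2csc(N/N=C/c3cccs3)n2)cc1` gives 84.2%.

Compound 4 `Cc1ccc(-c2csc(N/N=C/c3cccs3)n2)cc1` has not been measured yet.

Compound 1 and compound 2 differ in a single place, (methyl in place of fluoro on an aromatic carbon), and this change brought a number 12.2 percentage points lower from compound 1 to compound 2 (beyond the scatter). The cores of compound 1 and compound 3 differ too, but that difference is not broken down here; the two values alone sit close together. Compound 4 carries the same change relative to compound 3, (methyl in place of fluoro on an aromatic carbon), at the same place on the ring. Because the earlier step was a number 12.2 percentage points lower from compound 1 to compound 2 (beyond the scatter), a step of about a number 11.2 percentage points lower from compound 3 to compound 4 (beyond the scatter) is expected from compound 3 to compound 4 in this assay. Compound 4 is therefore estimated at 73%, most likely between 60% and 85%.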

Compound 4, a percentage reported as inhibition, at one concentration (the size of the read-out at that concentration, not a potency): 79.6%
Estimate against measurement, compound 4: 6.6 percentage points below; low and high end bracket the measured number.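

In this assay, putting methyl in place of fluoro on the second core gives a number 4.6 percentage points lower from compound 3 to compound 4 (within the scatter). Set beside the earlier step, the two cores cannot be told apart for this change: the same change on two cores in this assay, a number 12.2 percentage points lower (beyond the scatter) from compound 1 to compound 2 and a number 4.6 percentage points lower (within the scatter) from compound 3 to compound 4, 7.6 percentage points apart, within the scatter of two such steps. Among these compounds, this fits a change that carries over from one core to the other, but it rests on only two pairs, and it does not show that the step has one fixed size or that it would hold on a further core.

Only fluoro and methyl appear at this place on the ring. Going by these compounds, what a methoxy group, an amine or a carboxylic acid would do there remains open.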